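This account rests on a few compounds, and the source may have more. Where it says the series, first, only, none or still open, it means among the compounds named here.

For the measured compounds named here, in an assay on HEK293 cells for inhibition of melanin-concentrating hormone receptor 1 (Homo sapiens), read by radioligand binding (on this read-out higher numbers stand for weaker inhibition and lower numbers for stronger inhibition), compound 1 `CN(C)c1nc(N[C@H]2CC[C@@H](NC(=O)c3ccccc3F)CC2)nc2ccccc12` gives 170 nM, the lower of the two numbers measured so far. Compound 2 `CN(C)c1nc(NCC2CCC(CNCc3ccc(Br)cc3OC(F)(F)F)CC2)nc2ccccc12` gives 960 nM in this assay, a higher number beyond the scatter; the two are not a single-change pair, so nothing is read from that gap. Compound 3 `CN(C)c1nc(N[C@H]2CC[C@@H](NC(=O)c3ccc(Cl)c(Cl)c3)CC2)nc2ccccc12` differs from compound 1 in one place: 3,4-dichlorophenyl in place of 2-fluorophenyl on a carbonyl carbon. Going by the values given here, no measured pair shows this exchange, so the expectation rests on the structural change alone. The step from compound 1 to compound 3 is expected to be a modest gain, a 2.4-fold lower number from compound 1 to compound 3 (0.39 log units; beyond the scatter). Compound 3 is estimated at 70 nM, within 20 nM to 300 nM.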

Compound 3, half-maximal inhibitory concentration: 5 nM
Compound 3: the middle estimate sits 14-fold (1.15 log units) above what was measured; the whole stated range lies above it.
By their numbers in this assay, from the lowest: compound 3; then compound 1; then compound 2.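

For the compounds shown here, on a carbonyl carbon, the aryl group is a strong lever in this assay: 3,4-dichlorophenyl in place of 2-fluorophenyl gives a 34-fold lower number from compound 1 to compound 3 (1.53 log units; beyond the scatter), the first single-change step and a large one. The exchange alters both the halogen and the substitution pattern at once, and this one step does not separate the two. Nothing measured here accounts for the size of the step.

Still open, from the compounds shown here alone, is whether a phenyl carrying a single chlorine, or an unsubstituted phenyl, keeps part of this gain. Also open, going by these compounds, is how a pyridine ring or a methoxy-substituted phenyl would read at the same place.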